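Adding a methionine-type side chain to a purine glycinamide

The source may report more compounds than this note shows. Statements on the series, on what has been measured and on what is new or still open speak of the compounds shown alone.

The series concerns compound 1, `O=C(CN(c1ncnc2c1ncn2C1CCCCO1)C1CC1)NCC(=O)OCc1ccccc1`, whose effect is read in a functional assay on the whole organism (Tail, strain ICR) with Mus musculus as the target, in the tail flick test, with a stated time of 60 min, at a dose of 25 umol/kg by the oral route; on this read-out higher numbers stand for a stronger effect at the one dose given and lower numbers for a weaker effect. In this assay, within the data shown here, compound 1 gives 40.4%, the lowest of the two numbers known so far. The other measured member is compound 2, `NCCCC[C@H](NC(=O)CN(c1nc(Cl)nc2[nH]cnc12)C1CC1)C(=O)O`, and in this assay compound 2 gives 53.8%, a value that lies beyond the scatter above that of compound 1; since the two compounds differ in several places at once, their values show only that both fall in the same middle range of activity. The new member, compound 3, `CSCC[C@H](NC(=O)CN(c1ncnc2c1ncn2C1CCCCO1)C1CC1)C(=O)OCc1ccccc1`, differs from compound 1 in one place: 2-(methylsulfanyl)ethyl in place of hydrogen on a saturated chain carbon bound to an amide-type nitrogen and a carbonyl carbon. Among the measured compounds shown here, no single-point step within the measured pair tells how such a change plays out, so the expected step from compound 1 to compound 3 is set as a small rise, a number 6.6 percentage points higher from compound 1 to compound 3 (within the scatter), around the size of the usual scatter. Compound 3 is accordingly expected to give 47%, with a plausible range from 30% to 64%.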

Compound 3, a percentage reported as activity, at one dose (the size of the read-out at that dose, not a potency): 41%
The estimate for compound 3 lay 6 percentage points above the measured number; low and high end bracket the measured number.
By their numbers in this assay, from the lowest: compounds 1 and 3 (each within the scatter of the next); then compound 2.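

In this assay, among these compounds, the first single-place step, 2-(methylsulfanyl)ethyl in place of hydrogen on a saturated chain carbon bound to an amide-type nitrogen and a carbonyl carbon gives a number 0.6 percentage points higher from compound 1 to compound 3 (within the scatter) and so leaves compound 1 and compound 3 indistinguishable. This position therefore accepts a chain of 4 heavy atoms that includes a sulfur without any effect on this read-out that can be told from scatter, at this one dose and time. Nothing available explains this outcome.

A single substituent cannot show whether the position is insensitive in general, and a methyl or hydroxymethyl group at this carbon could test that. Going by these compounds, it also remains open whether a step would appear at another dose or time.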